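Cyclobutyl and cyclopentyl esters of two thienyl analogues

The compounds below may be only part of what the source reports. "The series", "measured", "known", "first", "only" and "open" are said of these compounds alone.

Measured compounds, all in an assay on membranes from HeLa cells for displacement of a labelled ligand from adenosine receptor A3 (Homo sapiens), read by scintillation counting, with a stated time of 180 min, tested at 1 uM; on this read-out lower numbers stand for less inhibition and higher numbers for more inhibition at the one concentration tested (going by the name of the read-out):
- compound 1 `CC1=C(C(=O)OC2CCC2)C(c2cccs2)NC(=O)N1`: 2%
- compound 2 `CC1=C(C(=O)OC2CCCC2)C(c2cccs2)NC(=O)N1`: 1%
- compound 3 `CC1=C(C(=O)OC2CCC2)C(c2ccsc2)NC(=O)N1`: 3%

Compound 2 differs from compound 1 by cyclopentyl in place of cyclobutyl on an oxygen next to a carbonyl group. The step in this assay is a number 1 percentage points lower from compound 1 to compound 2 (within the scatter). Compound 3 differs from compound 1 by thiophen-3-yl in place of thiophen-2-yl on a saturated ring carbon; the step is a number 1 percentage points higher from compound 1 to compound 3 (within the scatter). Within the data shown here, all three numbers sit close to the bottom of the read-out, and no pair among them is separated by more than the scatter, so nothing can be said about an order among compound 1, compound 2 and compound 3.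

Compound 4 `CC1=C(C(=O)OC2CCCC2)C(c2ccsc2)NC(=O)N1` has not been measured. It differs from compound 3 by cyclopentyl in place of cyclobutyl on an oxygen next to a carbonyl group. This is the same change as the one that turns compound 1 into compound 2, occurring twice among the compounds shown, and the place at which it is made is described in the same words in both cases. The two cores differ as given for compound 1 and compound 3.

The step from compound 3 to compound 4 in this assay is expected to be a number 1 percentage points lower from compound 3 to compound 4 (within the scatter), resting on the step from compound 1 to compound 2, which was a number 1 percentage points lower from compound 1 to compound 2 (within the scatter), and on the near-identical values of compound 1 and compound 3. Compound 4 is therefore estimated at 2%, with a range from 0% to 10%.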

Compound 4, a percentage reported as inhibition, at one concentration (the size of the read-out at that concentration, not a potency): 5%
The estimate for compound 4 lay 3 percentage points below the measured number; the range from low to high includes it.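

In this assay, cyclopentyl in place of cyclobutyl on an oxygen next to a carbonyl group gives a number 2 percentage points higher from compound 3 to compound 4 (within the scatter), and this step agrees with the earlier one on the other core as far as the read-out can tell: the same change on two cores in this assay, a number 1 percentage points lower (within the scatter) from compound 1 to compound 2 and a number 2 percentage points higher (within the scatter) from compound 3 to compound 4, 3 percentage points apart, within the scatter of two such steps. Thiophen-3-yl in place of thiophen-2-yl on a saturated ring carbon gives a number 4 percentage points higher from compound 2 to compound 4 (within the scatter), and this step likewise agrees with its earlier counterpart: the same change on two cores in this assay, a number 1 percentage points higher (within the scatter) from compound 1 to compound 3 and a number 4 percentage points higher (within the scatter) from compound 2 to compound 4, 3 percentage points apart, within the scatter of two such steps. Agreement between steps this small shows only that neither change moves the number beyond the scatter on these cores; it does not show that a step of real size would carry from one core to another, and that question remains untested in this set.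

The compounds shown leave open whether a longer chain or a benzyl group on the ester oxygen, or a phenyl group in place of the thiophene, would give a number clear of the scatter in this assay. Potency at this receptor also stays open, as each compound has a reading at only one concentration and all four numbers lie near the bottom of the read-out.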